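The source may report more compounds than this note shows. Statements on the series, on what has been measured and on what is new or still open speak of the compounds shown alone.

Measured so far:
- compound 1 `CC(C)(C)c1ccc(OCCCON2C(N)=NC(N)=NC23CCSCC3)cc1`: 86.6%
- compound 2 `COc1ccc(OCCCON2C(N)=NC(N)=NC23CCOCC3)cc1`: "not determined" (no result reported)

In an assay on isolated protein for inhibition of Dihydrofolate reductase (Homo sapiens), read by spectrophotometry, using NADPH, with stated times of 5 s and 6 min, tested at 50 uM (a higher number here means a stronger effect of the compound at the concentration tested, a lower number a weaker effect), compound 1 gives 86.6%, while for compound 2 the result is "not determined" (no result reported), so compound 2 stands at no single number. Compound 3 `Cc1cc(C)cc(OCCCON2C(N)=NC(N)=NC23CCOCC3)c1` differs from compound 2 by 3,5-dimethylphenyl in place of 4-methoxyphenyl on an oxygen on a saturated carbon. With no number for compound 2, the step to compound 3 cannot be measured against a starting point; only compound 1 gives an anchor in this assay, and a step of any clear direction cannot be stated from one value. Compound 3 is expected to give 75%, within a range from 45% to 95%.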

Compound 3, a percentage reported as inhibition, at one concentration (the size of the read-out at that concentration, not a potency): 88.6%
Compound 3: the middle estimate sits 13.6 percentage points below what was measured; the range from low to high includes it.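

In this assay, among these compounds, compound 2 stands at "not determined" (no result reported), so no step to compound 3 can be read. The compounds shown leave open how 3,5-dimethylphenyl in place of 4-methoxyphenyl changes the read-out. No other data here bear on this result.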